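The source may report more compounds than this note shows. Statements on the series, on what has been measured and on what is new or still open speak of the compounds shown alone.

Compound 3 `O=C(NS(=O)(=O)C1CC1)c1ccc(Nc2nc(NC3(c4ccc(Cl)cc4)CC3)nc(OCC(F)(F)F)n2)cc1` shares its core with compound 1 `CC(C)OC(=O)NCCS(=O)(=O)NC(=O)c1ccc(Nc2nc(NC3(c4ccc(Cl)cc4)CC3)nc(OCC(F)(F)F)n2)cc1` and compound 2 `O=C(NS(=O)(=O)c1ccccc1)c1ccc(Nc2nc(NC3(c4ccc(Cl)cc4)CC3)nc(OCC(F)(F)F)n2)cc1`. In an ADME assay on microsomes from liver (Homo sapiens) for metabolic stability, with a stated time of 10 min (on this read-out higher numbers stand for a more stable compound and lower numbers for a less stable compound), compound 3 gives 100%, compound 1 gives 100% and compound 2 gives 100%, so all three stand level. Compound 4 `CNC(=O)NCCS(=O)(=O)NC(=O)c1ccc(Nc2nc(NC3(c4ccc(Cl)cc4)CC3)nc(OCC(F)(F)F)n2)cc1` differs from compound 3 in one place: 2-((methylcarbamoyl)amino)ethyl in place of cyclopropyl on a sulfonyl sulfur. Among the measured compounds shown here, two measured steps bear on this change, since both swap the group on the sulfonyl sulfur: no change at the digits printed from compound 1 to compound 3 (within the scatter) and no change at the digits printed from compound 2 to compound 3 (within the scatter). Compound 1 already carries a 2-((isopropoxycarbonyl)amino)ethyl chain at that same place without any shift in this assay. Compound 4 is therefore expected to show a number 2 percentage points lower from compound 3 to compound 4 (within the scatter), no step beyond the scatter. Compound 4 is estimated at 98%, with a range from 85% to 100%.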

Compound 4, percent of the compound remaining: 97%
The estimate for compound 4 lay 1 percentage points above the measured number; the range from low to high includes it.
By their numbers in this assay, from the lowest: compounds 4, 1, 2 and 3 (each within the scatter of the next).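

On the sulfonyl sulfur, a chain as large as 2-((methylcarbamoyl)amino)ethyl fits the same flat picture as cyclopropyl and phenyl in this assay, with a number 3 percentage points lower from compound 3 to compound 4 (within the scatter) and a number 3 percentage points lower from compound 2 to compound 4 (within the scatter). The end of the chain can also be altered, as methylamino in place of isopropoxy on a carbonyl carbon gives a number 3 percentage points lower from compound 1 to compound 4 (within the scatter). Nothing at hand explains this result. On these data alone, whether a carboxylic acid or a free amine at the end of the chain, or a longer chain, would keep the read-out this high remains open.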